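A Small Trim on a Nearly Flat Cytotoxicity Series

The source may hold more compounds than are shown below. What is called first, only, known or untested is meant among the compounds shown, and "the series" means these compounds.

Going by the values given here, in an ADME assay on HEK293 cells (Homo sapiens) for cytotoxicity, with a stated time of 72 h (a lower number here means that less compound is needed, a higher number that more compound is needed for the effect), compound 1 (`CCc1ccc(NC(=O)Nc2cc(C)nc3ccccc23)cc1`) gives 16000 nM, the only true number so far. Compound 2 (`Cc1cc(NC(=O)Nc2cccc(C(N)=O)c2)c2ccccc2n1`) gives > 25000 nM, which is a limit of the assay and not a number. Compound 3 (`COc1ccc(NC(=O)Nc2cc(C)nc3ccccc23)cc1OC`) gives > 25000 nM, which is also a limit. The results so far therefore show (the limit of > 25000 nM in this assay, at which 2 of the 3 values shown sit), and compound 1 is the only one with an exact position on the scale.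

Compound 4 (`Cc1ccc(NC(=O)Nc2cc(C)nc3ccccc23)cc1`) differs from compound 1 in one place: hydrogen in place of methyl on a saturated chain carbon bound to an aromatic carbon. Put simply, hydrogen stands in place of methyl on a saturated chain carbon bound to an aromatic carbon, which turns ethyl into methyl.

Among the compounds with values here, no two measured compounds differ in just one place, so the data offer no direct precedent for this change. For so small a change, no step beyond the scatter is expected in this assay, and any drift would most likely be toward a higher number. Compound 1 at 16000 nM is the anchor for this expectation. The estimate amounts to a step of a 1.2-fold higher number from compound 1 to compound 4 (0.07 log units; within the scatter), which is expected to stay modest. The assay may also report only a limit. For compound 4 the estimated value is 19000 nM, with an expected range of 10000 nM to 30000 nM.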

Compound 4, half-maximal effective concentration: > 25000 nM
Compound 4 gave a limit, no number; the forecaster's own chance of this, stated with the estimate: 35%; at least 1.3-fold (0.11 log units) between middle value and limit.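

In this assay, going by these compounds alone, this is the first comparison between two compounds that differ in one place, and trimming ethyl to methyl on a saturated chain carbon bound to an aromatic carbon reads as an at least 1.5-fold higher number from compound 1 to compound 4 (0.19 log units; that floor lies within the scatter). This step is only a floor, since one end of it is a limit of the assay, so the true gap could be small or large, and the printed floor alone does not separate the two compounds beyond the usual scatter. The ethyl compound remains the only one in the series with a true number, and the methyl compound joins the others at the top of the scale: the limit of > 25000 nM in this assay, at which 3 of the 4 values shown sit.

From the compounds shown here alone, how far compound 4 lies past its limit stays open, and so does the question of whether the chain length at this place matters at all. A longer chain such as propyl, or an amine or a carboxylic acid in the same place, could show whether numbers lower than that of compound 1 can be reached and give this series a second true value to compare.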